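Swapping nitro for trifluoromethyl on a benzyloxy acetophenone

A few compounds are considered here, and "the series" means these few. Any claim that something is new, unique, unknown or untested is made for them only; others in the source may bear on it.

Of the compounds shown here, two sharing one core have been measured. Compound 1 `CC(=O)c1ccc(OCc2ccccc2C)cc1` carries a methyl on its benzyl ring, and in an assay on isolated protein for inhibition of Amine oxidase [flavin-containing] B (Homo sapiens), read by Amplex Red, with a stated time of 15 min (a higher number here means a weaker inhibitor, a lower number a stronger inhibitor), compound 1 gives 77.1 nM. Compound 2 `CC(=O)c1ccc(OCc2ccc([N+](=O)[O-])cc2)cc1` instead carries a nitro group, and in this assay compound 2 gives 96.5 nM. Compound 2 has the larger of the two numbers, yet the gap to compound 1 lies within the usual scatter of this assay, so the two compounds cannot be told apart on these data.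

Compound 3 `CC(=O)c1ccc(OCc2ccc(C(F)(F)F)cc2)cc1` has not yet been measured. It differs from compound 2 in one place: trifluoromethyl in place of nitro on an aromatic carbon. Among the compounds with values here, no measured pair in this set shows this particular change, so there is no step to lean on; the only guide is that the two measured compounds sit close together. The expectation for compound 3 is therefore a small step, if any, from compound 2, with no direction that can be claimed beyond the scatter; the estimated step is a 1.5-fold lower number from compound 2 to compound 3 (0.17 log units; within the scatter). For compound 3 in this assay the estimate is 65 nM, within a range from 20 nM to 200 nM.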

Compound 3, half-maximal inhibitory concentration: 77.8 nM
Compound 3: the middle estimate sits 1.2-fold (0.08 log units) below what was measured; the range from low to high includes it.
By their numbers in this assay, from the lowest: compounds 1, 3 and 2 (each within the scatter of the next).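

In this assay, placing trifluoromethyl where nitro stood, on an aromatic carbon para to a large group, gives a 1.2-fold lower number from compound 2 to compound 3 (0.09 log units; within the scatter), so compound 2 and compound 3 cannot be told apart. Within the data shown here, this is the first pair in the set that differs in one place, and it shows that this place accepts quite different groups without a readable difference: nitro has 2 hydrogen-bond acceptors and trifluoromethyl has 0, and 3 heavy atoms give way to 4, yet the result stays within the scatter. Nothing available explains why the exchange leaves so little trace in the assay.

As far as these compounds go, with only these two groups compared at this place, it remains open whether any group there can move the number beyond the scatter, and a carboxylic acid or an amine on the same aromatic carbon would test this with a group unlike either one. Compound 1 differs from compound 2 and compound 3 in more than one place, so it cannot settle this question.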